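Swapping the ring on the sulfur: compound 3 to compound 4

This account rests on a few compounds, and the source may have more. Where it says the series, first, only, none or still open, it means among the compounds named here.

Measured compounds:
Compound 1, `Cn1cnnc1SCC(=O)Nc1ccc(-c2nc(-c3ccccc3)c(-c3ccccc3)n2C)cc1`, gives 42.8% in a functional assay on MCF7 cells (Homo sapiens) for cytotoxicity, read by MTT assay, with a stated time of 24 h, tested at 1.6 ug/mL; on this read-out higher numbers stand for a stronger effect at the one concentration tested and lower numbers for a weaker effect.
Compound 2, `Cn1nnnc1SCC(=O)Nc1ccc(-c2nc(-c3ccccc3)c(-c3ccccc3)n2C)cc1`, gives 34.3% in this assay.
Compound 3, `Cc1nnc(SCC(=O)Nc2ccc(-c3nc(-c4ccccc4)c(-c4ccccc4)n3C)cc2)s1`, gives 37.5% in this assay.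

Compound 3 stands second highest of the three numbers, but neither neighbour is separated from it by more than the usual scatter: the step of a number 3.2 percentage points higher from compound 2 to compound 3 (within the scatter) and the step of a number 5.3 percentage points lower from compound 1 to compound 3 (within the scatter) both stay inside it. The same holds for a number 8.5 percentage points lower from compound 1 to compound 2 (within the scatter). Across these three compounds, each of which carries a different five-membered aromatic ring on the sulfur, the read-out in this assay has not moved beyond the scatter.

Compound 4, `Cn1c(-c2ccc(NC(=O)CSC3=NCCS3)cc2)nc(-c2ccccc2)c1-c1ccccc1`, is not yet measured. It differs from compound 3 at the same place: a group of 5 heavy atoms (3 carbon, 1 nitrogen, 1 sulfur; one five-membered non-aromatic ring with 2 hetero atoms) in place of a group of 6 heavy atoms (3 carbon, 2 nitrogen, 1 sulfur; one five-membered aromatic ring with 3 hetero atoms), on a sulfur. All three measured steps bear on this change, since each exchanges the group on the sulfur, and all were within the scatter. The expected step of a number 1.5 percentage points lower from compound 3 to compound 4 (within the scatter) is therefore none beyond the scatter, in no particular direction, though the entering ring is non-aromatic and thus a larger departure than any measured one. Compound 4 is estimated at 36% in this assay, with a range from 22% to 50%.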

Compound 4, a percentage reported as activity, at one concentration (the size of the read-out at that concentration, not a potency): 16.2%
For compound 4 the middle estimate is 19.8 percentage points above the measured one; measured number outside the range, below it.
By their numbers in this assay, from the lowest: compound 4; then compounds 2, 3 and 1 (each within the scatter of the next).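

With the non-aromatic five-membered ring on the sulfur, the read-out in this assay is lower against all three aromatic-ring compounds: a number 21.3 percentage points lower from compound 3 to compound 4 (beyond the scatter), a number 18.1 percentage points lower from compound 2 to compound 4 (beyond the scatter) and a number 26.6 percentage points lower from compound 1 to compound 4 (beyond the scatter). The earlier exchanges among the aromatic rings had shown no step beyond the scatter, so this position had looked tolerant of change; compound 4 shows that the read-out does depend on the group carried on this sulfur, at least for this departure from the aromatic rings. No measurement at hand speaks to the reason for this drop.

Compound 4 is the only compound with a non-aromatic ring here, and its ring also differs from the others in its hetero atoms and heavy atoms, so the compounds shown cannot say which of these differences goes with the lower number. They also leave open how the read-out would respond to a non-ring group on the sulfur, such as a methyl group or a short chain ending in an amine, and whether the gap would persist at concentrations other than the one tested.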